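The source may report more compounds than this note shows. Statements on the series, on what has been measured and on what is new or still open speak of the compounds shown alone.

Compound 1 `CCOc1ccc(-n2nncc2CN2C(=O)C3(C(C#N)=C(N)Oc4c(N)cc5nc6ccccc6nc5c43)c3ccccc32)cc1` gives 26800 nM in a functional assay on MCF7 cells (Homo sapiens) for antiproliferative activity, read by MTT assay, with a stated time of 48 h; on this read-out higher numbers stand for weaker inhibition and lower numbers for stronger inhibition. Compound 2 `N#CC1=C(N)Oc2c(N)cc3nc4ccccc4nc3c2C12C(=O)N(Cc1cnnn1-c1ccc([N+](=O)[O-])cc1)c1ccccc12` reaches only the assay limit, > 50000 nM, in this assay. Compound 3 `CCc1cccc(C)c1-n1nncc1CN1C(=O)C2(C(C#N)=C(N)Oc3c(N)cc4nc5ccccc5nc4c32)c2ccccc21` likewise sits at the limit, > 50000 nM, in this assay.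

So compound 3 has no number of its own, only a limit, and it shares that limit with one other compound (the limit of > 50000 nM in this assay, at which 2 of the 3 values shown sit). Compound 4 `N#CC1=C(N)Oc2c(N)cc3nc4ccccc4nc3c2C12C(=O)N(Cc1cnnn1-c1ccc(Cl)cc1[N+](=O)[O-])c1ccccc12` differs from compound 3 in one place: 4-chloro-2-nitrophenyl in place of 2-ethyl-6-methylphenyl on an aromatic nitrogen.

Going by the values given here, three measured steps touch this position. The step of an at least 1.8-fold higher number from compound 1 to compound 3 (0.27 log units; that floor lies within the scatter) and the step of an at least 1.8-fold higher number from compound 1 to compound 2 (0.27 log units; that floor lies within the scatter) both run from a number to a limit, while the step that the two limits leave unreadable from compound 2 to compound 3 cannot be read at all. Compound 2, which carries a nitro group on the same ring, already sits at the limit, so a nitro-bearing ring in compound 4 gives no reason to expect a readable gain. Compound 4 is therefore expected to stay near the limit, with the expected step of a number no higher from compound 3 to compound 4 (the limit leaves the size open). The estimate for compound 4 is 50000 nM, within 20000 nM to 120000 nM.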

Compound 4, half-maximal inhibitory concentration: > 50000 nM
Compound 4: a limit, no number; the forecaster's own chance of this, stated with the estimate: 65%; the middle value sits exactly at the limit.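

In this assay compound 4 also gives only a limit, so a ring carrying both chlorine and nitro, 4-chloro-2-nitrophenyl, brings back no readable number at this position. Compared with the only compound that has a number, the change gives an at least 1.8-fold higher number from compound 1 to compound 4 (0.27 log units; that floor lies within the scatter), and the steps among compound 2, compound 3 and compound 4 cannot be read, since both ends of each are limits. Three differently substituted rings now share one limit, and compound 1, with 4-ethoxyphenyl, is the only exception: the limit of > 50000 nM in this assay, at which 3 of the 4 values shown sit.

As far as these compounds go, how far compound 2, compound 3 and compound 4 actually lie from one another stays unknown. Also open, from the compounds shown here alone, is whether a longer chain such as butoxy in place of ethoxy, or an amine or a carboxylic acid on this ring, would give a number clearly apart from that of compound 1.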